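Moving the Fluorine on the Sulfonyl Aryl of Compound 1

This account rests on a few compounds, and the source may have more. Where it says the series, first, only, none or still open, it means among the compounds named here.

Compound 1 `COc1ccc(-c2c(S(=O)(=O)c3cccc(F)c3)cnc3cc(F)ccc23)cc1` gives 1.89 mL/min in an ADME assay on microsomes from liver (Homo sapiens) for metabolic stability, tested at 2.5 uM (a lower number here means slower removal, a higher number faster removal of the compound), the highest of the three measured numbers. Compound 2 `COc1ccc(S(=O)(=O)c2cnc3cc(F)ccc3c2-c2ccc(Cl)cc2)cc1` gives 1.28 mL/min in this assay, and compound 3 `O=S(=O)(c1cccc(F)c1)c1cnc2cc(F)ccc2c1-c1ccc(Cl)cc1` gives 0.98 mL/min in this assay, both within the scatter of compound 1. Compound 4 `COc1ccc(-c2c(S(=O)(=O)c3ccc(F)cc3)cnc3cc(F)ccc23)cc1` differs from compound 1 in one place: 4-fluorophenyl in place of 3-fluorophenyl on a sulfonyl sulfur. For the measured compounds named here, the one measured step on the sulfonyl sulfur is a 1.3-fold lower number from compound 2 to compound 3 (0.12 log units; within the scatter), and the other change, a 1.9-fold lower number from compound 1 to compound 3 (0.29 log units; within the scatter), also stayed within the scatter. Going by the values given here, no measured pair moves a fluorine within the same phenyl ring, so only a small step is expected: a 1.1-fold lower number from compound 1 to compound 4 (0.05 log units; within the scatter) is the estimate. Compound 4 is therefore expected to give about 1.7 mL/min in this assay, with a range from 0.9 mL/min to 3.2 mL/min.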

Compound 4, intrinsic clearance in a liver preparation (reported as CLH), per the amount of preparation that the assay uses: 1.77 mL/min
Compound 4: the middle estimate sits 1.0-fold (0.02 log units) below what was measured; the measured number falls inside the stated range.
By their numbers in this assay, from the lowest: compounds 3, 2, 4 and 1 (each within the scatter of the next).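

In this assay, for the compounds shown here, 4-fluorophenyl in place of 3-fluorophenyl on a sulfonyl sulfur gives a 1.1-fold lower number from compound 1 to compound 4 (0.03 log units; within the scatter) and is the first measured change that keeps the same ring and fluorine but moves the fluorine. In this one pair, the move leaves the number within the scatter. No evidence here gives a reason for this result. From the compounds shown here alone, it remains open how an amine or a carboxylic acid on this phenyl ring, in place of the fluorine, would behave. Going by these compounds, it also remains open whether the same fluorine move would behave alike in compound 3, which has chloro in place of methoxy.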